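A pyridine exchange on compound 2

The source may report more compounds than this note shows. Statements on the series, on what has been measured and on what is new or still open speak of the compounds shown alone.

Measured in a functional assay on HCT-116 cells (Homo sapiens) for cytotoxicity, read by sulforhodamine B assay, with a stated time of 48 h; on this read-out lower numbers stand for stronger inhibition and higher numbers for weaker inhibition:
compound 1 `CCCCNC(=O)N1Cc2c(NC(=O)c3ccccc3)nn(C(=O)c3ccccc3)c2C1`: 7470 nM
compound 2 `CC(=O)n1nc(NC(=O)c2ccccc2)c2c1CN(C(=O)c1cccc(F)c1)C2`: 21900 nM
compound 3 `CC(=O)n1nc(NC(=O)c2ccccc2)c2c1CN(S(=O)(=O)c1ccc([N+](=O)[O-])cc1)C2`: 22300 nM

Compound 2, at 21900 nM, sits within the scatter of compound 3. Its number is higher than that of compound 1, and that gap lies beyond the scatter, so compound 2 stands with compound 3 at the weaker end of this small set.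

The next compound to be tested is compound 4 `CC(=O)n1nc(NC(=O)c2ccccc2)c2c1CN(C(=O)c1ccncc1)C2`. It carries pyridin-4-yl in place of 3-fluorophenyl on a carbonyl carbon. Among the compounds with values here, no measured pair isolates this exchange, so the data offer no direct guide to it.

No step beyond the scatter is expected in this assay, in either direction. This expectation leans on compound 3, which has a different group on the ring nitrogen yet reads 22300 nM, within the scatter of compound 2. The estimated step of a 1.1-fold lower number from compound 2 to compound 4 (0.04 log units; within the scatter) is therefore small. For compound 4 the estimated value is 20000 nM, with an expected range of 8000 nM to 50000 nM.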

Compound 4, half-maximal inhibitory concentration: 10000 nM
Estimate against measurement, compound 4: 2.0-fold (0.30 log units) above; measured number inside the range.
By their numbers in this assay, from the lowest: compounds 1 and 4 (each within the scatter of the next); then compounds 2 and 3 (each within the scatter of the next).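

In this assay the exchange of 3-fluorophenyl for pyridin-4-yl on a carbonyl carbon gives a 2.2-fold lower number from compound 2 to compound 4 (0.34 log units; beyond the scatter) and so is a modest gain in inhibition rather than a silent swap. Within the data shown here, this is the first pair in the set that differs in one place, which shows that the aromatic group on this carbonyl carbon can change the read-out on its own while the rest of compound 2 stays the same.

From the compounds shown here alone, how plain phenyl or pyridin-3-yl would read on this carbonyl carbon remains open, as does whether the step depends on the fluorine leaving or on the pyridine nitrogen entering. Nothing in the available data accounts for the step.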